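A Dichlorophenyl Replaces Pyridin-4-yl on the Ring Nitrogen

The source may hold more compounds than are shown below. What is called first, only, known or untested is meant among the compounds shown, and "the series" means these compounds.

Compound 3 `Nc1scc(CN2CCN(c3ccncc3)CC2)c1C(=O)c1ccc(Cl)cc1` was tested in a functional assay on CHO cells with adenosine receptor A1 (Homo sapiens) as the target, read by cAMP accumulation and immunoassay, with a stated time of 6 min, tested at 0.01 uM (on this read-out lower numbers stand for a stronger effect and higher numbers for a weaker effect at the one concentration tested), where compound 3 gives -4%. This is the lowest of three numbers, but both neighbours lie within the scatter: compound 1 `CC(C)N1CCN(Cc2csc(N)c2C(=O)c2ccc(Cl)cc2)CC1` gives -1% and compound 2 `Nc1scc(CN2CCN(c3cccc(Cl)c3Cl)CC2)c1C(=O)c1ccc(Cl)cc1` gives 1%, with a number 3 percentage points lower from compound 1 to compound 3 (within the scatter) and a number 5 percentage points lower from compound 2 to compound 3 (within the scatter). Compound 4 `Nc1scc(CN2CCN(c3ccc(Cl)c(Cl)c3)CC2)c1C(=O)c1ccc(Cl)cc1` differs from compound 3 by 3,4-dichlorophenyl in place of pyridin-4-yl on an amine nitrogen in a ring. Within the data shown here, the steps that bear on this change are a number 2 percentage points higher from compound 1 to compound 2 (within the scatter) and a number 5 percentage points lower from compound 2 to compound 3 (within the scatter), both exchanges of the group on the same ring nitrogen, and neither moved the read-out beyond the scatter. Compound 4 is therefore expected to show no step beyond the scatter, a number 4 percentage points higher from compound 3 to compound 4 (within the scatter), and its value is estimated at 0%, within -10% to 10%.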

Compound 4, a percentage reported as activity, at one concentration (the size of the read-out at that concentration, not a potency): -1.2%
Beside the measured number, compound 4's estimate is 1.2 percentage points above it, and the stated range covers the measured number.
By their numbers in this assay, from the lowest: compounds 3, 4, 1 and 2 (each within the scatter of the next).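

In this assay, the 3,4-dichlorophenyl group on the ring nitrogen gives a number 2.8 percentage points higher from compound 3 to compound 4 (within the scatter), a number 2.2 percentage points lower from compound 2 to compound 4 (within the scatter) and a number 0.2 percentage points lower from compound 1 to compound 4 (within the scatter). The comparison with 2,3-dichlorophenyl thus adds a second chlorine pattern on the phenyl ring, and that exchange also stays inside the scatter, as do those with pyridin-4-yl and isopropyl. No measurement shown here explains this flat read-out. Going by these compounds, whether a benzyl group or a longer chain ending in a carboxylic acid on this nitrogen would move the number beyond the scatter remains open, as does whether these four compounds would separate at another concentration.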